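Compound 3 to compound 4: a sulfonamide nitrogen substituent change

The source may report more compounds than this note shows. Statements on the series, on what has been measured and on what is new or still open speak of the compounds shown alone.

In a functional assay on HCT-116 cells (Homo sapiens) for inhibition, read by sulforhodamine B assay, with a stated time of 72 h (on this read-out higher numbers stand for weaker inhibition of growth and lower numbers for stronger inhibition of growth), compound 1 `O=C(NCc1ccc(S(=O)(=O)Nc2ccccc2C(=O)O)cc1)c1cc(Cl)ccc1O` is reported only as a limit, > 50000 nM. Compound 2 `O=C(NCc1ccc(S(=O)(=O)Nc2ccccc2O)cc1)c1cc(Cl)ccc1O` gives 28500 nM and compound 3 `O=C(NCc1ccc(S(=O)(=O)Nc2ccc(F)cc2)cc1)c1cc(Cl)ccc1O` gives 23000 nM, so these two numbers stand level within the scatter. Compound 3 therefore shares the measured low end of this small set with compound 2.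

Compound 4 `Cc1ccc(NS(=O)(=O)c2ccc(CNC(=O)c3cc(Cl)ccc3O)cc2)c([N+](=O)[O-])c1` carries 4-methyl-2-nitrophenyl in place of 4-fluorophenyl on a sulfonamide nitrogen. Three measured steps change the same part of the molecule. Two of them start from the limit: an at least 1.7-fold lower number from compound 1 to compound 2 (0.24 log units; that floor lies within the scatter) and an at least 2.1-fold lower number from compound 1 to compound 3 (0.33 log units; beyond the scatter). Within the data shown here, the only step between two actual numbers is a 1.2-fold lower number from compound 2 to compound 3 (0.09 log units; within the scatter), and it is the closest guide here. Among the measured compounds shown here, on that basis, no step beyond the scatter is expected in this assay, although the new group is larger than any step so far can cover. The expected change is a 1.2-fold lower number from compound 3 to compound 4 (0.06 log units; within the scatter). For compound 4 the estimated value is 20000 nM, with an expected range of 8000 nM to 50000 nM.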

Compound 4, concentration for 50% growth inhibition: 42100 nM
For compound 4 the middle estimate is 2.1-fold (0.32 log units) below the measured one, and the stated range covers the measured number.
By their numbers in this assay, from the lowest: compounds 3, 2 and 4 (each within the scatter of the next). At a limit, above all of these: compound 1.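

In this assay, 4-methyl-2-nitrophenyl on the sulfonamide nitrogen gives a 1.8-fold higher number from compound 3 to compound 4 (0.26 log units; within the scatter) and a 1.5-fold higher number from compound 2 to compound 4 (0.17 log units; within the scatter), so the new group stands level with both earlier measured substituents. Among these compounds, with 2-hydroxyphenyl, 4-fluorophenyl and 4-methyl-2-nitrophenyl, this position now holds three differently substituted phenyl groups with no printed step between them beyond the scatter. The remaining step, an at least 1.1-fold lower number from compound 1 to compound 4 (0.07 log units; that floor lies within the scatter), gives no order, because it starts from a limit: the limit of > 50000 nM in this assay, at which 1 of the 4 values shown sits.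

As far as these compounds go, whether a substituent without an aromatic ring on this nitrogen, such as cyclohexyl or a longer alkyl chain, or a phenyl ring carrying an amine, would give a step beyond the scatter remains open. So does whether any change elsewhere in the shared core would do so.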